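The compounds below may be only part of what the source reports. "The series", "measured", "known", "first", "only" and "open" are said of these compounds alone.

Of the compounds shown here, two have been measured in a functional assay on Malme-3M cells (Homo sapiens); on this read-out higher numbers stand for weaker inhibition of growth and lower numbers for stronger inhibition of growth. Compound 1, `COc1cc(CSc2cc(Cl)c(-c3nc(-c4ccc(Cl)cc4)no3)cc2S(=O)(=O)NC(=N)NO)cc(OC)c1OC`, gives 7760 nM in this assay. Compound 2, `N=C(NO)NS(=O)(=O)c1cc(-c2nc(-c3ccccc3)no2)c(Cl)cc1SCc1ccccc1`, gives 1800 nM in this assay. Among these two numbers compound 1 stands highest, so it is the weaker inhibitor of growth, and the gap between compound 1 and compound 2 is beyond the scatter of repeated measurements.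

Compound 3, `COc1cc(CSc2cc(Cl)c(-c3nnc(-c4ccc(Cl)cc4)s3)cc2S(=O)(=O)NC(=N)NO)cc(OC)c1OC`, has not yet been measured in this assay. It is made from compound 1 by one change:
5-(4-chlorophenyl)-1,3,4-thiadiazol-2-yl in place of 3-(4-chlorophenyl)-1,2,4-oxadiazol-5-yl on an aromatic carbon
Both groups carry the same 4-chlorophenyl ring, and the five-membered ring keeps three hetero atoms, with sulfur taking the place of oxygen. Going by the values given here, no measured pair shows this swap, so its effect is unknown here.

For compound 3 a step from compound 1 no larger than the usual scatter, in either direction, is expected, written as a 1.4-fold lower number from compound 1 to compound 3 (0.15 log units; within the scatter). The estimate for compound 3 in this assay is therefore 5500 nM, with a range from 1800 nM to 17000 nM.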

Compound 3, concentration for 50% growth inhibition: 97700 nM
Compound 3: the middle estimate sits 18-fold (1.25 log units) below what was measured, and the stated range ends below it.
By their numbers in this assay, from the lowest: compound 2; then compound 1; then compound 3.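

This position on the shared core is far from indifferent. In this assay, placing 5-(4-chlorophenyl)-1,3,4-thiadiazol-2-yl where 3-(4-chlorophenyl)-1,2,4-oxadiazol-5-yl stood gives a 13-fold higher number from compound 1 to compound 3 (1.10 log units; beyond the scatter) and therefore much weaker inhibition of growth, even though the two groups match in heavy-atom count, ring types, and counted hydrogen-bond donors and acceptors. Nothing measured here bears on why this exchange has so large an effect.

On these data alone, this single exchange alters both the ring's hetero atoms and their arrangement, so it remains open which of these matters. A 5-(4-chlorophenyl)-1,3,4-oxadiazol-2-yl group at this position would separate the two, and an open-chain amide in place of the five-membered ring would test whether any aromatic ring is needed there.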